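Swapping the aryl piperazine cap of compound 1 for cyclohexyl

The compounds below may be only part of what the source reports. "The series", "measured", "known", "first", "only" and "open" are said of these compounds alone.

Of the compounds shown here, three sharing a common core have been measured in an assay on isolated protein for inhibition of long-chain fatty acid transport protein 1 (Homo sapiens), read by scintillation counting, with a stated time of 20 min; on this read-out lower numbers stand for stronger inhibition and higher numbers for weaker inhibition. Compound 1 `O=C(CN1CCN(c2ccc(F)cc2)CC1)Nc1nc2c(s1)CCCC2` gives 77 nM, the lowest number of the three. Compound 2 `O=C(CN1CCN(c2ccc(F)cc2)CC1)Nc1nc2ccccc2s1` gives 490 nM, and compound 3 `O=C(CN1CCN(c2ccc(F)cc2)CC1)Nc1nc2c(s1)CCC2` gives 490 nM; each of these sits well beyond the usual scatter above compound 1, so compound 1 stands as the strongest inhibitor of the set.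

Compound 4 `O=C(CN1CCN(C2CCCCC2)CC1)Nc1nc2c(s1)CCCC2` has not been measured. It differs from compound 1 in one place: cyclohexyl in place of 4-fluorophenyl on an amine nitrogen in a ring. Going by the values given here, none of the measured pairs shows this particular change, and the measured compounds vary only in the ring fused to the core, so nothing here tells how the cap on the ring nitrogen matters. The writer therefore expects a step from compound 1 to compound 4 of moderate size, more likely toward a higher number than a lower one, though a result within the scatter cannot be excluded; the estimated step is a 2.6-fold higher number from compound 1 to compound 4 (0.41 log units; beyond the scatter). For compound 4 the estimate in this assay is 200 nM, within a range of 50 nM to 800 nM.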

Compound 4, half-maximal inhibitory concentration: > 1000 nM
Compound 4: no number, only a limit; the forecaster's own chance of this, stated with the estimate: 5%; middle value at least 5.0-fold (0.69 log units) from the limit.
By their numbers in this assay, from the lowest: compound 1; then compounds 2 and 3 (each within the scatter of the next). At a limit, above all of these: compound 4.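

In this assay compound 4 gives > 1000 nM, which is a limit of the assay and not a number. The earlier compounds shown here varied only in the ring fused to the core, and this result shows that the cap on the ring nitrogen matters as well: cyclohexyl in place of 4-fluorophenyl brings an at least 12-fold higher number from compound 1 to compound 4 (1.11 log units; beyond the scatter). How large the step truly is cannot be read from this result: the limit of > 1000 nM in this assay, at which 1 of the 4 values shown sits.

With only this one cap change shown, it stays open whether the step follows the loss of the fluorine or the loss of the aromatic ring, and a plain phenyl cap on the same nitrogen would separate the two. Also open, as far as these compounds go, is how a 4-chlorophenyl or a benzyl cap would read in this assay.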